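A fluoro-for-chloro swap on the benzyl ring of compound 3

The source may hold more compounds than are shown below. What is called first, only, known or untested is meant among the compounds shown, and "the series" means these compounds.

Compound 1 `CCCCNc1nc(-c2ccccc2)nc2c1nnn2Cc1ccccc1F`: 4.3 nM
Compound 2 `CCCCCCNc1nc(-c2ccccc2)nc2c1nnn2Cc1ccccc1`: 13.2 nM
Compound 3 `CCCCCCNc1nc(-c2ccccc2)nc2c1nnn2Cc1ccccc1Cl`: 31 nM

In an assay on Cerebral cortex for displacement of a labelled ligand from adenosine receptor A1 (Bos taurus) (on this read-out higher numbers stand for weaker inhibition and lower numbers for stronger inhibition), compound 3 gives 31 nM, the highest of the three numbers measured. Its nearest neighbour is compound 2, which gives 13.2 nM, and the measured step of a 2.3-fold higher number from compound 2 to compound 3 (0.37 log units; beyond the scatter) is the only one that touches the benzyl ring directly. Going by the values given here, compound 1, which carries a shorter chain on the amine together with a fluoro group on the benzyl ring, gives 4.3 nM in this assay; no single-point step links it to compound 3, so its value can only be read alongside the others.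

Compound 4 `CCCCCCNc1nc(-c2ccccc2)nc2c1nnn2Cc1ccccc1F` has not yet been measured. It differs from compound 3 as follows: fluoro in place of chloro on an aromatic carbon. Among the compounds with values here, the one step that bears on this change is the one from hydrogen to chloro, which was modest and raised the number. Fluoro is expected to land between the unsubstituted and the chloro cases, so the step from compound 3 to compound 4 is expected to be a 1.7-fold lower number from compound 3 to compound 4 (0.24 log units; within the scatter) in this assay. Compound 4 is therefore estimated at 18 nM, with a range from 7 nM to 45 nM.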

Compound 4, inhibition constant: 25 nM
Compound 4: the middle estimate sits 1.4-fold (0.14 log units) below what was measured; low and high end bracket the measured number.
By their numbers in this assay, from the lowest: compound 1; then compounds 2, 4 and 3 (each within the scatter of the next, the first and the last beyond it).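

In this assay the halogen swap at this place carries little weight: exchanging chloro for fluoro gives a 1.2-fold lower number from compound 3 to compound 4 (0.09 log units; within the scatter), and fluoro in place of hydrogen gives a 1.9-fold higher number from compound 2 to compound 4 (0.28 log units; within the scatter), so fluoro cannot be told apart from either chloro or hydrogen here, although chloro and hydrogen are separated by a 2.3-fold higher number from compound 2 to compound 3 (0.37 log units; beyond the scatter). Going by these compounds alone, with the 2-fluorobenzyl group held constant, ethyl in place of hydrogen on the chain gives a 5.8-fold higher number from compound 1 to compound 4 (0.76 log units; beyond the scatter), a step beyond the scatter and larger than any of the steps on the aromatic ring, which gives a direct reading of the chain on the amine for the first time in this set. Nothing shown offers a reason for the size of any of these steps.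

As far as these compounds go, whether the chain step keeps its size with hydrogen or chloro on the benzyl ring remains open, as only the fluoro pair reads it directly. Also open, from the compounds shown here alone, is whether a bromo, a methyl or a methoxy group on this aromatic carbon would stand apart from the hydrogen, fluoro and chloro cases.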